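This account rests on a few compounds, and the source may have more. Where it says the series, first, only, none or still open, it means among the compounds named here.

Going by the values given here, compound 1 `Cc1ccc(NC2=CC(=O)c3c(nc4n3[C@H]3OC[C@@H](O)[C@H]3OC4)C2=O)cc1C` is one of two compounds measured in a functional assay on HeLa cells (Homo sapiens) for inhibition, read by sulforhodamine B assay (a higher number here means a weaker inhibitor, a lower number a stronger inhibitor), where compound 1 gives 4320 nM. Its companion, compound 2 `COc1cccc(NC2=CC(=O)c3nc4n(c3C2=O)[C@H]2OC[C@@H](O)[C@H]2OC4)c1`, gives 4280 nM in this assay, and the two numbers sit within the usual scatter of each other, so neither can be told apart from the other on this evidence. Both carry a substituted phenylamino group on the shared core.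

Compound 3 `O=C1C(N2CCCC2)=CC(=O)c2c1nc1n2[C@H]2OC[C@@H](O)[C@H]2OC1` has not yet been measured in this assay. Relative to compound 1 it carries the change (pyrrolidin-1-yl in place of (3,4-dimethylphenyl)amino on a double-bonded ring carbon). Among the compounds with values here, no measured pair yet shows what swapping the aromatic amine for a saturated ring amine does here, so the direction of the step is open. The expectation is a modest step of a 1.5-fold higher number from compound 1 to compound 3 (0.18 log units; within the scatter), at the edge of the scatter, toward a somewhat weaker inhibitor. Compound 3 is therefore expected to give about 6500 nM in this assay, within the range 1500 nM to 28000 nM.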

Compound 3, half-maximal inhibitory concentration: > 16000 nM
Compound 3: a limit, no number (the forecaster's own chance of this, stated with the estimate: 15%); middle value at least 2.4-fold (0.39 log units) away from the limit.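

At this double-bonded ring carbon, pyrrolidin-1-yl in place of (3,4-dimethylphenyl)amino gives an at least 3.7-fold higher number from compound 1 to compound 3 (0.56 log units; beyond the scatter) in this assay, so this position is not indifferent to the group it carries. The reading for compound 3 is a limit of the assay and not a number: the limit of > 16000 nM in this assay, at which 1 of the 3 values shown sits. This single change replaces an aromatic ring of carbon and a hydrogen-bond donor with a five-membered non-aromatic ring and no donor, and one step cannot show which of these differences matters.

The compounds shown do not separate those differences, which an open-chain amine such as butylamino or a benzylamino group at the same carbon could begin to do. As far as these compounds go, how a saturated ring of another kind, such as piperidine or morpholine, reads at this position also remains open.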